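Limits only: a step to the methoxyphenyl analogue

This account rests on a few compounds, and the source may have more. Where it says the series, first, only, none or still open, it means among the compounds named here.

Compound 1, `Cc1ccc2[nH]c(=O)c(CN(Cc3ccc(OC(C)C)cc3)Cc3ccc(C(C)(C)C)cc3)cc2c1`: in a toxicity assay on MDCK cells (Canis lupus familiaris) for cytotoxicity, read by crystal violet staining, with a stated time of 48 h (on this read-out higher numbers stand for lower toxicity in this test and lower numbers for higher toxicity in this test), compound 1 gives > 5000 nM, a limit of the assay.
Compound 2, `Cc1ccc2[nH]c(=O)c(CN(Cc3ccc(C(C)(C)C)cc3)C(C)c3ccc(F)cc3)cc2c1`: in this assay compound 2 gives > 33000 nM, again a limit.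
Compound 3, `Cc1ccc2[nH]c(=O)c(CN(Cc3ccc(C(C)(C)C)cc3)[C@@H](C)c3ccc(F)cc3)cc2c1`: in this assay compound 3 gives > 5000 nM, also a limit.

Compound 3 thus stands at a limit, as do the other two measured compounds; no number is known for any of them. The unmeasured compound 4, `COc1ccc(C(C)N(Cc2ccc(C(C)(C)C)cc2)Cc2cc3cc(C)ccc3[nH]c2=O)cc1`, differs from compound 3 by 1-(4-methoxyphenyl)ethyl in place of 1-(4-fluorophenyl)ethyl on an amine nitrogen. The measured steps that could inform this change are a step that the two limits leave unreadable from compound 1 to compound 3 and a step that the two limits leave unreadable from compound 1 to compound 2, both unreadable because the limit of > 33000 nM in this assay, at which 1 of the 3 values shown sits, and the limit of > 5000 nM in this assay, at which 2 of the 3 values shown sit, cap every value; a step that the two limits leave unreadable from compound 2 to compound 3 is likewise unreadable, the pair differing only in that (the fact that one of compounds 2 and 3 is drawn with a defined configuration and the other without, at the place where they differ). With nothing readable, and all three measured compounds sitting at limits, compound 4 is expected to sit at a limit as well, so the step from compound 3 to compound 4 is estimated as a step that the limit leaves unreadable from compound 3 to compound 4. Compound 4 is therefore expected to give 20000 nM in this assay, with a range from 5000 nM to 100000 nM.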

Compound 4, half-maximal cytotoxic concentration: > 5000 nM
Compound 4 was reported as a limit; the forecaster's own chance of this, stated with the estimate: 75%; the middle value lies beyond the limit too.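

Compound 4, like compounds 1, 2 and 3, stands at a limit in this assay, so none of its steps to those three compounds can be read. The compounds shown leave open where any of the four true values lies, and whether methoxy in place of fluoro shifts it.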